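A Bromine-for-Chlorine Step Below the Assay Floor

A few compounds are considered here, and "the series" means these few. Any claim that something is new, unique, unknown or untested is made for them only; others in the source may bear on it.

Of the compounds shown here, three sharing one core have been tested in a functional assay on KB cells (Homo sapiens) for inhibition; on this read-out higher numbers stand for weaker inhibition and lower numbers for stronger inhibition. Compound 1, `FC(F)(F)c1ccc(Cn2c(Cl)nc3cc(Cl)c(Cl)cc32)cc1`, carries a chloro group on the five-membered aromatic ring with 2 nitrogen. In this assay compound 1 gives > 100000 nM, which is a limit of the assay and not a number. Compound 2, `FC(F)(F)c1cc(Cn2c(Cl)nc3cc(Cl)c(Cl)cc32)cc(C(F)(F)F)c1`, differs from compound 1 in more than one place, and the difference between the two cores is not broken down here. In this assay compound 2 gives > 100000 nM, again a limit rather than a measured number. Compound 3, `FC(F)(F)c1ccc(Cn2c(Br)nc3cc(Cl)c(Cl)cc32)cc1`, is compound 1 with bromo in place of chloro on an aromatic carbon. In this assay compound 3 gives > 100000 nM, also a limit. The step that the two limits leave unreadable from compound 1 to compound 3 therefore cannot be read, since (the limit of > 100000 nM in this assay, at which 3 of the 3 values shown sit).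

Compound 4, `FC(F)(F)c1cc(Cn2c(Br)nc3cc(Cl)c(Cl)cc32)cc(C(F)(F)F)c1`, has not been measured. It is related to compound 2 as compound 3 is to compound 1: bromo in place of chloro on an aromatic carbon. The surroundings of the changed carbon are described in the same words for both pairs, so this is the same change. Because (the limit of > 100000 nM in this assay, at which 3 of the 3 values shown sit), there is no readable step on which to size the expected change, and the expectation can only rest on the limits already reached. For compound 4 the step is expected to be a step that the limit leaves unreadable from compound 2 to compound 4. Compound 4 is estimated at 200000 nM in this assay, within a range from 50000 nM to 1000000 nM, and it is expected that the assay will most likely again report only a limit.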

Compound 4, half-maximal inhibitory concentration: 70000 nM
Compound 4: the middle estimate sits 2.9-fold (0.46 log units) above what was measured; the measured number falls inside the stated range.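

Carried onto the core of compound 2, bromo in place of chloro on an aromatic carbon gives, in this assay, an at least 1.4-fold lower number from compound 2 to compound 4 (0.15 log units; that floor lies within the scatter), and compound 4 at 70000 nM is the only readable number among the compounds shown. Compound 2 gives > 100000 nM, which is a limit of the assay and not a number, so the step is only a floor, and since that floor lies within the scatter, it does not establish a real gain from the change. The matching step from compound 1 to compound 3 cannot be read, so there is no pair of sizes to set side by side, and the data show neither that the change carries over from one core to the other nor that it fails to, a comparison that stays closed because of the crowding of the values at one limit: the limit of > 100000 nM in this assay, at which 3 of the 4 values shown sit.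

The compounds shown leave open whether an amine or a nitrile on the same aromatic carbon, in place of chloro or bromo, would give a number clearly clear of the limit. They also leave open what a carboxylic acid or a longer chain in place of the trifluoromethyl groups would do on this read-out.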